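The source may report more compounds than this note shows. Statements on the series, on what has been measured and on what is new or still open speak of the compounds shown alone.

Measured so far in an ADME assay on liver (Homo sapiens) for metabolic stability, read by LC-MS, using microsomes and NADPH; a higher number here means that more of the compound is left, a lower number that less of the compound is left:
- compound 1 `CCCN(Cc1ccc(OCCn2c(=O)ccn(C)c2=O)c(OC)c1)C(CC(=O)O)c1ccc(Cl)cc1` gives 61%
- compound 2 `COc1cc(CN(CC2CC2)C(CC(=O)O)c2ccc(Cl)cc2)ccc1OCCn1c(=O)ccn(C)c1=O` gives 55%
- compound 3 `CCCCN(Cc1ccc(OCCn2c(=O)ccn(C)c2=O)c(OC)c1)C(CC(=O)O)c1ccc(Cl)cc1` gives 38%

Compound 1 shares the upper level with compound 2, as a number 6 percentage points lower from compound 1 to compound 2 (within the scatter) shows. Compound 3 stands apart from both, with a number 23 percentage points lower from compound 1 to compound 3 (beyond the scatter) and a number 17 percentage points lower from compound 2 to compound 3 (beyond the scatter) on record.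

Compound 4 `CCCN(Cc1ccc(OCCn2c(=O)ccn(C)c2=O)c(OC)c1)C(CC(=O)O)c1ccc2c(c1)CCO2` is still unmeasured. Against compound 1 it shows (a group of 9 heavy atoms (8 carbon, 1 oxygen; one five-membered non-aromatic ring with 1 hetero atom, one six-membered aromatic ring of carbon only) in place of a group of 7 heavy atoms (6 carbon, 1 chlorine; one six-membered aromatic ring of carbon only), on a saturated chain carbon bound to an amine nitrogen and a saturated chain carbon), so the 4-chlorophenyl gives way to a larger group with no common name.

Going by the values given here, none of the measured steps changes that group. All three alter the chain on the amine nitrogen, so they offer only a scale, running from within the scatter to modest. The data hold no measurement at the new place, which leaves the direction uncertain, with a slight lean downward in this assay as the working expectation.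

The estimated change is a number 13 percentage points lower from compound 1 to compound 4 (beyond the scatter), a modest step at most. For compound 4 the expected value is 48%, with an estimated range from 28% to 68%.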

Compound 4, percent of the compound remaining: 83%
The estimate for compound 4 lay 35 percentage points below the measured number; measured number above the stated range.
By their numbers in this assay, from the lowest: compound 3; then compounds 2 and 1 (each within the scatter of the next); then compound 4.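

In this assay, going by these compounds alone, the saturated chain carbon bound to an amine nitrogen and a saturated chain carbon now has its first reading: the larger group with no common name in place of 4-chlorophenyl gives a number 22 percentage points higher from compound 1 to compound 4 (beyond the scatter) as the only upward step. Changes at this position can therefore raise the read-out, by a step of the same modest class as the larger steps from changing the chain on the amine nitrogen. No measured information accounts for the rise.

This single pair does not separate losing the chlorine from gaining the oxygen-containing five-membered ring. Plain phenyl and 4-methoxyphenyl at this position would help to divide those contributions, and a butyl chain on the amine nitrogen would test whether the rise carries over.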